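Compound 3 to compound 4: swapping the oxanyl group

The source may report more compounds than this note shows. Statements on the series, on what has been measured and on what is new or still open speak of the compounds shown alone.

In a physicochemical assay for solubility, at pH 6.8 (on this read-out lower numbers stand for lower solubility and higher numbers for higher solubility), compound 1 `Cc1c(COCCCCOCC2(C)COC2)[nH]c2ccccc2c1=O` gives >= 100000 nM, which is a limit of the assay. Compound 2 `Cc1c(COCCCCO)[nH]c2ccccc2c1=O` gives >= 100000 nM, also a limit. Compound 1 and compound 2 therefore share (the limit of >= 100000 nM in this assay, at which 2 of the 3 values shown sit). Among the compounds with values here, compound 3 `Cc1c(COc2cc(OCC3CCOCC3)ccn2)[nH]c2ccccc2c1=O` gives 36000 nM, the only actual number in the set.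

Compound 4 `Cc1c(COc2cc(OCCC(C)(C)O)ccn2)[nH]c2ccccc2c1=O` differs from compound 3 in one place: 2-hydroxy-2-methylpropyl in place of oxan-4-yl on a saturated chain carbon bound to an oxygen on an aromatic ring. Cut one bond further out, (oxan-4-yl)methoxy gives way to 3-hydroxy-3-methylbutoxy, so the chain carries a hydroxy group and no ring.

Within the data shown here, the only measured step is a step that the two limits leave unreadable from compound 1 to compound 2, with hydrogen in place of (3-methyloxetan-3-yl)methyl on an oxygen on a saturated carbon. That step is a different change and offers no size to carry over. The one weak pointer to direction is compound 2 at >= 100000 nM, a limit reached by a chain that also ends in a hydroxy group. On that thin basis, the expected change is a modest rise in this assay, and the result could itself reach the limit. The expected step is a 1.9-fold higher number from compound 3 to compound 4 (0.29 log units; within the scatter). For compound 4 the estimated value is 70000 nM, with an expected range of 30000 nM to 100000 nM.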

Compound 4, solubility: 85000 nM
Compound 4: the middle estimate sits 1.2-fold (0.08 log units) below what was measured; low and high end bracket the measured number.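

In this assay, within the data shown here, 2-hydroxy-2-methylpropyl in place of oxan-4-yl on a saturated chain carbon bound to an oxygen on an aromatic ring gives a 2.4-fold higher number from compound 3 to compound 4 (0.37 log units; beyond the scatter), the first step in this set whose size can be read. The number at this position therefore moves with the swap, and the move lies beyond the usual scatter: a six-membered non-aromatic ring with 0 hydrogen-bond donors leaves, and a group with no ring and 1 hydrogen-bond donor enters. The only earlier step cannot be read, and the measurable room above the new value is limited: the limit of >= 100000 nM in this assay, at which 2 of the 4 values shown sit.

The swap removes the ring and brings in the hydroxy group in a single change, so the compounds shown do not separate the share of each in the step. Also open, as far as these compounds go, is what a primary amine or a carboxylic acid in place of 2-hydroxy-2-methylpropyl would give in this assay, and whether such a value would remain a number or become a limit.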